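This account rests on a few compounds, and the source may have more. Where it says the series, first, only, none or still open, it means among the compounds named here.

Values so far in an ADME assay on cells (Astrocyte, Rattus norvegicus, strain Wistar) for inhibition, read by sulforhodamine B assay, with a stated time of 72 h; a higher number here means that more compound is tolerated, a lower number that less compound is tolerated
compound 1 `O=C(/C=C/c1ccc([N+](=O)[O-])o1)c1ccc(I)cc1` gives 68200 nM
compound 2 `CSc1ccc(C(=O)/C=C/c2ccc([N+](=O)[O-])o2)cc1` gives 28400 nM
compound 3 `O=C(/C=C/c1ccc([N+](=O)[O-])o1)c1ccc(-n2ccnc2)cc1` gives 45300 nM

Compound 3 at 45300 nM lies within the scatter of both other measured compounds, with a 1.5-fold lower number from compound 1 to compound 3 (0.18 log units; within the scatter) and a 1.6-fold higher number from compound 2 to compound 3 (0.20 log units; within the scatter) as its two steps. Compound 4 `O=C(/C=C/c1ccc([N+](=O)[O-])o1)c1ccc(C2CCCCC2)cc1` carries cyclohexyl in place of 1H-imidazol-1-yl on an aromatic carbon, and the counted difference reads cyclohexyl in place of 1H-imidazol-1-yl on an aromatic carbon in full. Going by the values given here, no measured compound carries cyclohexyl, so the nearest evidence is the exchanges among compound 1, compound 2 and compound 3 on that carbon. The largest of these, a 2.4-fold lower number from compound 1 to compound 2 (0.38 log units; beyond the scatter), is modest, and the two exchanges involving 1H-imidazol-1-yl stay within the scatter. Nothing measured gives a direction for cyclohexyl. In this assay no step beyond the scatter is therefore expected, and the estimated step is a 1.0-fold lower number from compound 3 to compound 4 (0.00 log units; within the scatter). The estimate for compound 4 is 45000 nM, with an expected range from 20000 nM to 100000 nM.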

Compound 4, half-maximal cytotoxic concentration: 57200 nM
Beside the measured number, compound 4's estimate is 1.3-fold (0.10 log units) below it; the measured number falls inside the stated range.
By their numbers in this assay, from the lowest: compounds 2, 3, 4 and 1 (each within the scatter of the next, the first and the last beyond it).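

In this assay, going by these compounds alone, cyclohexyl is the first group at this carbon, para to a large group, with a non-aromatic ring of carbon only and no hydrogen-bond acceptors, yet exchanging it for 1H-imidazol-1-yl leaves the number within the scatter (a 1.3-fold higher number from compound 3 to compound 4 (0.10 log units; within the scatter)). Cyclohexyl also stays within the scatter of the other two groups (a 2.0-fold higher number from compound 2 to compound 4 (0.30 log units; within the scatter); a 1.2-fold lower number from compound 1 to compound 4 (0.08 log units; within the scatter)), so compound 4 adds no further step beyond the scatter, and the only such step among the four compounds remains the one between compound 1 and compound 2. No measured property of these compounds is available to bear on this result.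

On these data alone, whether a carboxylic acid or a primary amine at this carbon would give a step beyond the scatter remains open. Also open, as far as these compounds go, is how the number responds to exchanges elsewhere on the shared core, such as replacing the nitro group.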